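Moving the Pyridine Nitrogen in a Phenylsulfonyl Compound

The source may report more compounds than this note shows. Statements on the series, on what has been measured and on what is new or still open speak of the compounds shown alone.

Within the data shown here, in a functional assay on QGY-7703 cells (Homo sapiens) for cytotoxicity, read by MTT assay, with a stated time of 24 h (on this read-out higher numbers stand for weaker inhibition and lower numbers for stronger inhibition), compound 2 `O=C1/C(=C/c2cccnc2)CN(S(=O)(=O)c2ccccc2)C/C1=C\c1ccccc1C(F)(F)F` gives 6240 nM, the higher of the two numbers so far. Among the measured compounds shown here, the only other measured compound, compound 1 `CN1C/C(=C\c2cccnc2)C(=O)/C(=C/c2ccccc2C(F)(F)F)C1`, gives 2910 nM. For the measured compounds named here, the single measured step, a 2.1-fold higher number from compound 1 to compound 2 (0.33 log units; beyond the scatter), is modest and reflects phenylsulfonyl in place of methyl on an amine nitrogen in a ring. Compound 3 `O=C1/C(=C/c2ccncc2)CN(S(=O)(=O)c2ccccc2)C/C1=C\c1ccccc1C(F)(F)F` keeps the phenylsulfonyl group and differs elsewhere: pyridin-4-yl in place of pyridin-3-yl on a double-bonded chain carbon bound to a double-bonded ring carbon. This places pyridin-4-yl in place of pyridin-3-yl on a double-bonded chain carbon bound to a double-bonded ring carbon. Going by the values given here, no measured step touches that place, so the data offer no direct guide to its size or direction. In this assay, no change beyond the scatter is therefore expected. The expected result is a 1.1-fold lower number from compound 2 to compound 3 (0.05 log units; within the scatter). For compound 3, the estimated value is 5500 nM, with an expected range of 2500 nM to 12000 nM.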

Compound 3, half-maximal inhibitory concentration: 6210 nM
Beside the measured number, compound 3's estimate is 1.1-fold (0.05 log units) below it, and the stated range covers the measured number.
By their numbers in this assay, from the lowest: compound 1; then compounds 3 and 2 (each within the scatter of the next).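

In this assay the change of pyridin-3-yl to pyridin-4-yl on a double-bonded chain carbon bound to a double-bonded ring carbon gives a 1.0-fold lower number from compound 2 to compound 3 (0.00 log units; within the scatter) and so stays within the scatter. Among these compounds, this is the first measured reading at this place, and with the phenylsulfonyl group on the amine nitrogen in a ring, the two pyridine attachments cannot be told apart by their numbers. Nothing among the data offers a reason for this result. As far as these compounds go, it remains open whether pyridin-2-yl or a plain phenyl ring at this place would give a number beyond the scatter. From the compounds shown here alone, it also remains open whether the same exchange would read alike with methyl on the ring nitrogen, or with an acetyl or benzyl group there.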